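A few compounds are considered here, and "the series" means these few. Any claim that something is new, unique, unknown or untested is made for them only; others in the source may bear on it.

Values in an ADME assay on HepG2 cells (Homo sapiens) for cytotoxicity, read by MTT assay, with a stated time of 72 h; a lower number here means that less compound is tolerated, a higher number that more compound is tolerated:
- compound 1 `COc1ccc(-c2cc(Cl)cn3c([N+](=O)[O-])c(CS(=O)(=O)c4ccccc4)nc23)cc1`: > 3900 nM, a limit
- compound 2 `CCN(CC)c1ccc(-c2cc(Cl)cn3c([N+](=O)[O-])c(CS(=O)(=O)c4ccccc4)nc23)cc1`: > 15600 nM, a limit
- compound 3 `N#Cc1ccc(-c2cc(Cl)cn3c([N+](=O)[O-])c(CS(=O)(=O)c4ccccc4)nc23)cc1`: > 3900 nM, a limit

Compound 2 is known only as a limit, > 15600 nM. None of the three compounds has a measured number in this assay.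

Compound 4 `O=[N+]([O-])c1c(CS(=O)(=O)c2ccccc2)nc2c(-c3cccc(CO)c3)cc(Cl)cn12` has 3-(hydroxymethyl)phenyl in place of the 4-(diethylamino)phenyl of compound 2, on the same aromatic carbon: 3-(hydroxymethyl)phenyl in place of 4-(diethylamino)phenyl on an aromatic carbon.

For the measured compounds named here, three measured steps bear on a change at this carbon: a step that the two limits leave unreadable from compound 1 to compound 2, a step that the two limits leave unreadable from compound 1 to compound 3 and a step that the two limits leave unreadable from compound 2 to compound 3. None has a readable size, so they give no measure of how far a change here moves the value, and no direction can be drawn from them. The expected outcome is therefore no defined shift, and compound 4 may well be reported as a limit too. The estimated step is a step that the limit leaves unreadable from compound 2 to compound 4, and this carries no expected direction. For compound 4 the estimated value is 16000 nM, with an expected range from 5000 nM to 50000 nM.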

Compound 4, half-maximal cytotoxic concentration: > 25000 nM
Compound 4 was reported as a limit; the forecaster's own chance of this, stated with the estimate: 75%; middle value at least 1.5-fold (0.19 log units) from the limit.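

Compound 4 is also known only as a limit, so its steps from compound 1, compound 2 and compound 3 cannot be read in this assay. The compounds shown leave open the concentration at which any of them reaches half-maximal cytotoxicity, and whether these groups differ at all.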